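Acylation of the methylamino nitrogen: from compound 2 to compound 3

The source may hold more compounds than are shown below. What is called first, only, known or untested is meant among the compounds shown, and "the series" means these compounds.

In a functional assay on the whole organism (strain Sprague-Dawley CD) for inhibition, with Rattus norvegicus as the target, read by paw edema, at a dose of 10 mg/kg by the intraperitoneal route (on this read-out lower numbers stand for a weaker effect and higher numbers for a stronger effect at the one dose given), compound 1 `CCOC(=O)C(=O)Nc1ccccc(O)c1=O` gives 5%, while compound 2 `CCOC(=O)C(=O)Nc1ccccc(NC)c1=O` gives 73%, the higher of the two numbers measured; the step of a number 68 percentage points higher from compound 1 to compound 2 (beyond the scatter) came with methylamino in place of hydroxy on an aromatic carbon. Compound 3 `CCOC(=O)C(=O)Nc1ccccc(N(C)C(=O)C(=O)OCC)c1=O` differs from compound 2 by (ethoxycarbonyl)carbonyl in place of hydrogen on a nitrogen on an aromatic ring. Among the compounds with values here, no measured step touches the nitrogen itself, so the single known step offers no direct guide, and the expectation stays wide. Compound 3 is estimated at 50%, expected to lie between 15% and 85%. That estimate corresponds to an expected step of a number 23 percentage points lower from compound 2 to compound 3 (beyond the scatter).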

Compound 3, a percentage reported as inhibition, in the whole organism at one dose (the size of the read-out at that dose, not a potency): 26%
Compound 3: the middle estimate sits 24 percentage points above what was measured, and the stated range covers the measured number.
By their numbers in this assay, from the lowest: compound 1; then compound 3; then compound 2.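

Compound 2 had shown only that methylamino on the aromatic carbon goes with a strong effect. In this assay, the nitrogen of that group now also proves to matter: (ethoxycarbonyl)carbonyl in place of its hydrogen gives a number 47 percentage points lower from compound 2 to compound 3 (beyond the scatter), so this substitution is not tolerated without a large loss at the one dose given. Nothing available accounts for the drop. On these data alone, it remains open whether a smaller acetyl group on this nitrogen would keep more of the effect, or how a carboxylic acid in place of the ethyl ester would read.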